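Swapping the aryl group on the shared core

The source may report more compounds than this note shows. Statements on the series, on what has been measured and on what is new or still open speak of the compounds shown alone.

Measured so far:
compound 1 `CCCCN(CC)c1cc(C)nc2c1NC(=O)CN2c1ccc(C)cc1C`: 6.8%
compound 2 `CCCCN(CC)c1cc(C)nc2c1NC(=O)CN2c1ccc(C)cc1Br`: 5.5%

Compound 1 `CCCCN(CC)c1cc(C)nc2c1NC(=O)CN2c1ccc(C)cc1C` and compound 2 `CCCCN(CC)c1cc(C)nc2c1NC(=O)CN2c1ccc(C)cc1Br` share one core and differ only in one aromatic substituent. In an assay on HEK-293T cells for displacement of a labelled ligand from corticotropin-releasing factor receptor 2 (Homo sapiens), read by scintillation counting, with a stated time of 2 h, tested at 1 uM (on this read-out lower numbers stand for less inhibition and higher numbers for more inhibition at the one concentration tested (going by the name of the read-out)), compound 1 gives 6.8% and compound 2 gives 5.5%. The step of a number 1.3 percentage points lower from compound 1 to compound 2 (within the scatter) is within the scatter, so the two numbers are best read as the same. Compound 2 holds the lower of the two numbers, but that says nothing given the scatter.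

Compound 3 `CCCCN(CC)c1cc(C)nc2c1NC(=O)CN2c1ccc(Cl)cc1Cl` is not yet measured. It differs from compound 2 by 2,4-dichlorophenyl in place of 2-bromo-4-methylphenyl on a nitrogen on an aromatic ring in a ring. Within the data shown here, the only step seen so far, bromo for methyl on the same aryl group, did not move the number beyond the scatter; no step that changes both substituents at once exists. The two measured compounds sit near the floor of this read-out, and nothing in the data points to a rise.

Compound 3 is therefore expected to stay in the same low region, with a step of about a number 1.5 percentage points higher from compound 2 to compound 3 (within the scatter) in this assay. The estimate for compound 3 is 7%, with a range from -5% to 20%.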

Compound 3, a percentage reported as inhibition, at one concentration (the size of the read-out at that concentration, not a potency): 0.9%
Beside the measured number, compound 3's estimate is 6.1 percentage points above it; the measured number falls inside the stated range.
By their numbers in this assay, from the lowest: compounds 3, 2 and 1 (each within the scatter of the next).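

In this assay, the exchange of 2-bromo-4-methylphenyl for 2,4-dichlorophenyl on the nitrogen comes to a number 4.6 percentage points lower from compound 2 to compound 3 (within the scatter) and the exchange of 2,4-dimethylphenyl for 2,4-dichlorophenyl comes to a number 5.9 percentage points lower from compound 1 to compound 3 (within the scatter) on the same read-out. The earlier pair had shown only that one substituent on the aryl group could change without moving the number beyond the scatter; these steps show the same when both substituents differ, so the three aryl groups on this nitrogen cannot be told apart and all remain in the same low region. No independent evidence bears on why the numbers stay together.

What the compounds leave open is whether an aryl group carrying a methoxy, an amine or a carboxylic acid, or a pyridine ring in place of the phenyl ring, would lift the number out of this low region. Going by these compounds, it also remains open whether a change elsewhere on the shared core, such as a longer chain on the amine in place of butyl or ethyl, would do more than any change at this position.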